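Lengthening the Alkyne of a Pyranone Inhibitor

This account rests on a few compounds, and the source may have more. Where it says the series, first, only, none or still open, it means among the compounds named here.

Compound 1 `C#Cc1cc(C)oc(=O)c1` was tested in a functional assay on A2780 cells (Homo sapiens) for inhibition (a higher number here means a weaker inhibitor, a lower number a stronger inhibitor), where compound 1 gives 3100 nM; this is the only definite number shown. Compound 2 `CCCCc1cc(C)oc(=O)c1` reaches only a limit of the assay, > 50000 nM. Compound 3 `CCCCCC/C=C/c1cc(C)oc(=O)c1` likewise sits at a limit, > 50000 nM. Within the data shown here, the one measured step that bears on the question is an at least 16-fold higher number from compound 1 to compound 2 (1.20 log units; beyond the scatter), a change that ends at the limit of > 50000 nM in this assay, at which 2 of the 3 values shown sit. Compound 4 `CCCCCC#Cc1cc(C)oc(=O)c1` keeps the triple bond of compound 1 but carries pentyl in place of hydrogen on a triple-bonded carbon. Since every longer side chain so far has pushed the number to the limit, a weakening is expected for compound 4, estimated as a 9.7-fold higher number from compound 1 to compound 4 (0.99 log units; beyond the scatter). Compound 4 is therefore expected near 30000 nM, within 6000 nM to 60000 nM.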

Compound 4, half-maximal inhibitory concentration: 2900 nM
Compound 4: the middle estimate sits 10-fold (1.01 log units) above what was measured; the measured number lies below the stated range.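

With pentyl in place of hydrogen on the triple-bonded carbon, the two compounds cannot be told apart: a 1.1-fold lower number from compound 1 to compound 4 (0.03 log units; within the scatter). A longer side chain therefore does not by itself raise the number, provided the triple bond stays. Compound 2 and compound 3, which lack the triple bond, give limits of the assay rather than numbers: the limit of > 50000 nM in this assay, at which 2 of the 4 values shown sit.

On these data alone, how much more this triple-bonded carbon can carry remains open. A longer chain, or a pentyl chain ending in an amine or a carboxylic acid, could either keep the number or raise it.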